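Methyl to methoxy on the ester-side aromatic carbon

The source may hold more compounds than are shown below. What is called first, only, known or untested is meant among the compounds shown, and "the series" means these compounds.

Compound 3 `Cc1ccc(C(=O)Oc2ccc(NC(=O)Nc3ccccc3)cc2)cc1` gives 18900 nM in a functional assay on A549 cells (Homo sapiens) for antiproliferative activity, read by MTT assay, with a stated time of 48 h (on this read-out higher numbers stand for weaker inhibition and lower numbers for stronger inhibition), the lowest of the three numbers measured. Compound 2 `O=C(Nc1ccccc1)Nc1ccc(OC(=O)c2ccc(F)cc2)cc1` gives 38500 nM and compound 1 `O=C(Nc1ccccc1)Nc1ccc(OC(=O)c2ccc([N+](=O)[O-])cc2)cc1` gives 120000 nM. All three differ only in the group on an aromatic carbon of a six-membered aromatic ring of carbon only: a 3.1-fold lower number from compound 1 to compound 2 (0.49 log units; beyond the scatter), a 6.3-fold lower number from compound 1 to compound 3 (0.80 log units; beyond the scatter), and a 2.0-fold lower number from compound 2 to compound 3 (0.31 log units; beyond the scatter). Within the data shown here, each step is modest and beyond the scatter, and methyl gives the lowest number so far.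

Compound 4 `COc1ccc(C(=O)Oc2ccc(NC(=O)Nc3ccccc3)cc2)cc1` changes compound 3 at the same place: methoxy in place of methyl on an aromatic carbon. Among the measured compounds shown here, no measured step covers methoxy, so the three steps only show that changes at this carbon have moved the number modestly. With nothing on these data to set methoxy apart from methyl, the expected step is a 1.2-fold higher number from compound 3 to compound 4 (0.07 log units; within the scatter), within or close to the scatter. Compound 4 is therefore estimated at 22000 nM, expected to fall between 8000 nM and 60000 nM.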

Compound 4, half-maximal inhibitory concentration: 60200 nM
Estimate against measurement, compound 4: 2.7-fold (0.44 log units) below, outside the stated range (above it).
By their numbers in this assay, from the lowest: compound 3; then compounds 2, 4 and 1 (each within the scatter of the next, the first and the last beyond it).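

Methoxy in place of methyl is a real step at this carbon: in this assay it gives a 3.2-fold higher number from compound 3 to compound 4 (0.50 log units; beyond the scatter), so the two small groups cannot be treated as interchangeable here. Methoxy does not separate from fluoro, with a 1.6-fold higher number from compound 2 to compound 4 (0.19 log units; within the scatter), or from nitro, with a 2.0-fold lower number from compound 1 to compound 4 (0.30 log units; within the scatter), even though fluoro and nitro separate from each other, with a 3.1-fold lower number from compound 1 to compound 2 (0.49 log units; beyond the scatter), and compound 3 alone now stands beyond the scatter of all three other compounds. No information at hand accounts for the methyl-to-methoxy step.

Still open, as far as these compounds go, is whether the low number belongs to methyl alone or extends to an ethyl group or a longer chain at this carbon. An amine or a carboxylic acid in the same place would show how far the number can move from that of compound 3 at 18900 nM.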